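Amidoxime series: combined chloro and fluoro substitution on the aryl

A few compounds are considered here, and "the series" means these few. Any claim that something is new, unique, unknown or untested is made for them only; others in the source may bear on it.

Compound 1 `Cc1cccc(/C(=N/O)Nc2ccc([N+](=O)[O-])c3nonc23)c1` carries a 3-methylphenyl group on the carbon with a double bond to nitrogen. In an assay on isolated protein for inhibition of Indoleamine 2,3-dioxygenase 1 (Homo sapiens), read by spectrophotometry, with a stated time of 1 h (a lower number here means a stronger inhibitor, a higher number a weaker inhibitor), compound 1 gives 163 nM. Within the three measured numbers compound 1 stands second highest; its nearest neighbour is compound 2 `O=[N+]([O-])c1ccc(N/C(=N\O)c2cccc(Cl)c2)c2nonc12`, which in this assay gives 184 nM, and the furthest is compound 3 `O=[N+]([O-])c1ccc(N/C(=N\O)c2ccc(F)cc2)c2nonc12`, which gives 100 nM. All three sit close together.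

Compound 4 `O=[N+]([O-])c1ccc(N/C(=N\O)c2ccc(F)c(Cl)c2)c2nonc12` has not yet been measured. It differs from compound 1 as follows: 3-chloro-4-fluorophenyl in place of 3-methylphenyl on a carbon with a double bond to nitrogen.

Among the compounds with values here, two measured steps bear on this change. The step of a 1.1-fold higher number from compound 1 to compound 2 (0.05 log units; within the scatter) covers the chloro for methyl exchange. The step of a 1.6-fold lower number from compound 1 to compound 3 (0.21 log units; within the scatter) covers the arrival of a fluorine on the aryl ring. The step of a 1.8-fold lower number from compound 2 to compound 3 (0.26 log units; within the scatter) adds nothing beyond the scatter either. Since neither part of the change moved the number beyond the scatter on its own, the combined change in compound 4 is expected to leave this assay essentially unchanged, with the step of a 1.3-fold lower number from compound 1 to compound 4 (0.10 log units; within the scatter) taken as the estimate.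

Compound 4 is therefore expected to give 130 nM in this assay, with a range from 60 nM to 300 nM.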

Compound 4, half-maximal inhibitory concentration: 158 nM
For compound 4 the middle estimate is 1.2-fold (0.08 log units) below the measured one; the measured number falls inside the stated range.
By their numbers in this assay, from the lowest: compounds 3, 4, 1 and 2 (each within the scatter of the next).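

Working notes: in this assay, the 3-chloro-4-fluorophenyl group on the carbon with a double bond to nitrogen is accommodated without a change beyond the scatter, with a 1.0-fold lower number from compound 1 to compound 4 (0.01 log units; within the scatter). The earlier compounds shown here carried only one substituent on this aryl ring, whereas the two new single-place comparisons test each halogen with the other already present: the added chloro gives a 1.6-fold higher number from compound 3 to compound 4 (0.20 log units; within the scatter), and the added fluoro gives a 1.2-fold lower number from compound 2 to compound 4 (0.07 log units; within the scatter). Nothing available explains why these steps stay within the scatter.

Methyl, chloro and fluoro on the aryl ring leave all four compounds within the range already seen, so it remains open whether any substituent at this position can move the number beyond the scatter. A carboxylic acid, an amine or a longer chain such as butyl on the aryl ring would be a sharper test of how much change this position accepts.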